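A few compounds are considered here, and "the series" means these few. Any claim that something is new, unique, unknown or untested is made for them only; others in the source may bear on it.

Measured so far:
compound 1, `O=C1OC[C@H](Cc2ccccc2)[C@H]1Cc1ccccc1`, 77000 nM
compound 2, `O=C1OC[C@H](Cc2ccccc2)[C@H]1Cc1ccccc1F`, 72000 nM
compound 3, `O=C1OC[C@H](Cc2ccccc2)[C@H]1Cc1cccc(F)c1`, 75000 nM

In a functional assay on HL-60 cells (Homo sapiens) for cytotoxicity, read by WST assay, with a stated time of 48 h (a higher number here means that more compound is needed for the effect, a lower number that less compound is needed), compound 1 gives 77000 nM. Its value lies within the usual scatter of both other numbers: the step of a 1.1-fold lower number from compound 1 to compound 2 (0.03 log units; within the scatter) and the step of a 1.0-fold lower number from compound 1 to compound 3 (0.01 log units; within the scatter) are each too small to separate the compounds, and the step of a 1.0-fold higher number from compound 2 to compound 3 (0.02 log units; within the scatter) likewise shows nothing beyond the scatter. Within the data shown here, on the numbers so far, compound 1 therefore stands together with compounds 2 and 3 rather than apart from them.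

Compound 4, `Cc1ccc(C[C@H]2C(=O)OC[C@@H]2Cc2ccccc2)cc1`, differs from compound 1 in one place: methyl in place of hydrogen on an aromatic carbon. The change sits on the same kind of position as the two changes already measured, an aromatic carbon of the shared core, where a fluoro entering in place of hydrogen gave a 1.1-fold lower number from compound 1 to compound 2 (0.03 log units; within the scatter) and a 1.0-fold lower number from compound 1 to compound 3 (0.01 log units; within the scatter). Among the measured compounds shown here, those steps bear on the present one only loosely, since a methyl is not a fluoro, but they are the only guide available, and both were within the scatter. The expected step is therefore a 1.0-fold lower number from compound 1 to compound 4 (0.01 log units; within the scatter), nothing beyond the scatter in either direction. Compound 4 is estimated at 75000 nM, with a range from 30000 nM to 190000 nM.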

Compound 4, half-maximal effective concentration: 44000 nM
Compound 4: the middle estimate sits 1.7-fold (0.23 log units) above what was measured; measured number inside the range.
By their numbers in this assay, from the lowest: compounds 4, 2, 3 and 1 (each within the scatter of the next).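

In this assay, the change from phenyl to 4-methylphenyl puts a carbon group rather than a fluoro on an aromatic carbon, para to a large group, and the step is a 1.8-fold lower number from compound 1 to compound 4 (0.24 log units; within the scatter), larger in size than either fluoro step on compound 1 but still not separating the pair. The comparisons with the two fluoro compounds read the same way, with a 1.7-fold lower number from compound 3 to compound 4 (0.23 log units; within the scatter) and a 1.6-fold lower number from compound 2 to compound 4 (0.21 log units; within the scatter), so this first carbon substituent leaves all four compounds standing together and shows that a methyl at this place, like a fluoro on the aromatic carbons already tested, does not move the number beyond the scatter. Nothing at hand offers an explanation for the size of this step.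

The compounds shown leave open whether any group at this place can separate itself from compound 1, as an ethyl chain, a methoxy, an amine or a carboxylic acid might or might not. They also leave open whether a methyl on another aromatic carbon of the shared core would give a similar step.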